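Moving a Bromine Around the Aryl Ether of Compound 3

The compounds below may be only part of what the source reports. "The series", "measured", "known", "first", "only" and "open" are said of these compounds alone.

Three compounds share one core and differ only in the aromatic group attached to an oxygen on that core. Compound 1 `COc1ccccc1Oc1nc(Nc2ccc(C#N)cc2)nc2ccccc12` carries a 2-methoxyphenyl there, and in an ADME assay on MT4 cells (Homo sapiens) for cytotoxicity, read by MTT assay, with a stated time of 4 days (on this read-out higher numbers stand for lower toxicity in this test and lower numbers for higher toxicity in this test), compound 1 gives 150000 nM. Compound 2 `N#Cc1ccc(Nc2nc(Oc3ccc(F)cc3)c3ccccc3n2)cc1` carries a 4-fluorophenyl; in this assay compound 2 reaches only a limit of the test, > 351000 nM. Compound 3 `Cc1cc(Br)c(Oc2nc(Nc3ccc(C#N)cc3)nc3ccccc23)c(Br)c1` carries a 2,6-dibromo-4-methylphenyl, and in this assay compound 3 gives 25000 nM. The steps run an at least 2.3-fold higher number from compound 1 to compound 2 (0.36 log units; beyond the scatter), a 6.0-fold lower number from compound 1 to compound 3 (0.78 log units; beyond the scatter) and an at least 14-fold lower number from compound 2 to compound 3 (1.14 log units; beyond the scatter). Compound 3 therefore holds the lowest number among the measured set, with compound 1 nearest. For compound 2 only the limit is known (the limit of > 351000 nM in this assay, at which 1 of the 3 values shown sits).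

Compound 4 `Cc1cc(Br)cc(Br)c1Oc1nc(Nc2ccc(C#N)cc2)nc2ccccc12` has 2,4-dibromo-6-methylphenyl in place of 2,6-dibromo-4-methylphenyl on an oxygen on an aromatic ring. Going by the values given here, no measured step rearranges groups on the same ring; the two steps ending at compound 3 show that swapping this group for a different one gives modest or large changes, whereas here both bromines and the methyl remain. A small step is therefore expected, a 1.2-fold higher number from compound 3 to compound 4 (0.08 log units; within the scatter), likely within the scatter. Compound 4 is expected to give 30000 nM, with a range from 10000 nM to 100000 nM.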

Compound 4, half-maximal cytotoxic concentration: 150000 nM
Compound 4: middle estimate off by 5.0-fold (0.70 log units), on the low side; measured number outside the range, above it.
By their numbers in this assay, from the lowest: compound 3; then compounds 1 and 4 (each within the scatter of the next). At a limit, above all of these: compound 2.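

Rearranging the same atoms on this ring is enough to shift the read-out: 2,4-dibromo-6-methylphenyl in place of 2,6-dibromo-4-methylphenyl gives a 6.0-fold higher number from compound 3 to compound 4 (0.78 log units; beyond the scatter) in this assay, so where the groups sit matters here, and not only which groups are present. Carrying two bromines and a methyl does not by itself go with the lowest number, as 2,4-dibromo-6-methylphenyl and 2-methoxyphenyl show no change at the digits printed from compound 1 to compound 4 (within the scatter). The remaining step, an at least 2.3-fold lower number from compound 2 to compound 4 (0.36 log units; beyond the scatter), gives only a bound and not an exact size, as one end of it is a limit: the limit of > 351000 nM in this assay, at which 1 of the 4 values shown sits.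

The bromine and methyl positions change together between these two compounds, and the shift cannot be assigned to either group alone. As far as these compounds go, how a single bromine, or an amine or carboxylic acid in place of the methyl, would read in this assay remains open.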